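Swapping trifluoromethyl for (methylsulfonyl)methyl on the alkyne-linked ring

The source may report more compounds than this note shows. Statements on the series, on what has been measured and on what is new or still open speak of the compounds shown alone.

Compound 2 `O=C(O)COc1ccc(Cl)cc1C#Cc1cccc(C(F)(F)F)c1` gives 92 nM in an assay on CHO cells for displacement of a labelled ligand from prostaglandin D2 receptor 2 (Homo sapiens), read by scintillation counting; a lower number here means a stronger inhibitor, a higher number a weaker inhibitor. Compound 1 `CN(C)C(=O)c1cccc(C#Cc2cc(Cl)ccc2OCC(=O)O)c1` gives 52 nM, and compound 3 `Cn1ccnc1C#Cc1cc(Cl)ccc1OCC(=O)O` gives 1470 nM, so compound 2 sits between them, close to compound 1 and far from compound 3. Compound 4 `CS(=O)(=O)Cc1cccc(C#Cc2cc(Cl)ccc2OCC(=O)O)c1` differs from compound 2 in one place: (methylsulfonyl)methyl in place of trifluoromethyl on an aromatic carbon. Among the measured compounds shown here, the only measured step at that position is a 1.8-fold higher number from compound 1 to compound 2 (0.25 log units; within the scatter), which replaced dimethylcarbamoyl with trifluoromethyl and stayed within the scatter. On that basis the reverse kind of exchange, putting a polar group back, is expected to move little: a step of a 1.3-fold lower number from compound 2 to compound 4 (0.12 log units; within the scatter) is estimated, with no change beyond the scatter. Compound 4 is therefore expected to give about 70 nM, within 30 nM to 160 nM.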

Compound 4, inhibition constant: 48 nM
Beside the measured number, compound 4's estimate is 1.5-fold (0.16 log units) above it; the range from low to high includes it.
By their numbers in this assay, from the lowest: compounds 4, 1 and 2 (each within the scatter of the next); then compound 3.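

In this assay, exchanging trifluoromethyl for (methylsulfonyl)methyl gives a 1.9-fold lower number from compound 2 to compound 4 (0.28 log units; within the scatter), and exchanging dimethylcarbamoyl for it gives a 1.1-fold lower number from compound 1 to compound 4 (0.03 log units; within the scatter). Among the compounds shown here, three differently built groups at this position therefore cannot be told apart by this measurement, as no step among them goes beyond the scatter. No measurement is available that would explain this.

Going by these compounds, it remains open whether this flat picture holds for an amine, a carboxylic acid or a longer chain at the same position. A group that moves the number beyond the scatter is still to be seen on this ring.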